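This account rests on a few compounds, and the source may have more. Where it says the series, first, only, none or still open, it means among the compounds named here.

Measured in a functional assay on DU-145 cells (Homo sapiens) for antiproliferative activity, read by MTT assay, with a stated time of 3 days; a higher number here means a weaker inhibitor, a lower number a stronger inhibitor: compound 1 `CCS(=O)(=O)Nc1ccc(-c2cc(=O)c3c(O)cc(OC)c(OC(C)C)c3o2)cc1` gives 17000 nM; compound 2 `COc1cc(O)c2c(=O)cc(-c3ccc(NC(=O)NC4CC4)cc3)oc2c1OC(C)C` gives 15600 nM; compound 3 `COc1cc(O)c2c(=O)cc(-c3ccc(NC(=O)N4CCN(C)CC4)cc3)oc2c1OC(C)C` gives 12500 nM.

Compound 3 holds the lowest of the three numbers, yet its neighbours sit close: a 1.2-fold lower number from compound 2 to compound 3 (0.10 log units; within the scatter) and a 1.4-fold lower number from compound 1 to compound 3 (0.13 log units; within the scatter), so the three compounds cannot be told apart. Compound 4 `COc1cc(O)c2c(=O)cc(-c3ccc(NC(=O)N4CC(C)NC(C)C4)cc3)oc2c1OC(C)C` differs from compound 3 at the carbonyl carbon: 3,5-dimethylpiperazin-1-yl in place of 4-methylpiperazin-1-yl on a carbonyl carbon. Within the data shown here, the one step at the same place, a 1.2-fold lower number from compound 2 to compound 3 (0.10 log units; within the scatter), and the further exchange at the ring nitrogen, a 1.1-fold lower number from compound 1 to compound 2 (0.04 log units; within the scatter), both stayed within the scatter, so no step beyond the scatter is expected in this assay for compound 4, which is estimated at 13000 nM (range 6000 nM to 28000 nM), meaning an expected 1.0-fold higher number from compound 3 to compound 4 (0.02 log units; within the scatter).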

Compound 4, half-maximal inhibitory concentration: 41900 nM
For compound 4 the middle estimate is 3.2-fold (0.51 log units) below the measured one, and the stated range ends below it.
By their numbers in this assay, from the lowest: compounds 3, 2 and 1 (each within the scatter of the next); then compound 4.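

Among these compounds, the carbonyl carbon is not indifferent to the group it carries: in this assay, where the earlier steps stayed within the scatter, a 3.4-fold higher number from compound 3 to compound 4 (0.53 log units; beyond the scatter) lies beyond it, as do a 2.7-fold higher number from compound 2 to compound 4 (0.43 log units; beyond the scatter) and a 2.5-fold higher number from compound 1 to compound 4 (0.39 log units; beyond the scatter). Compound 4 is therefore the weakest of the four, and 3,5-dimethylpiperazin-1-yl, unlike 4-methylpiperazin-1-yl, brings a hydrogen-bond donor. Nothing available accounts for this loss of activity.

Still open, going by these compounds, is how unsubstituted piperazin-1-yl or morpholin-4-yl on the same carbonyl carbon would compare, which would help separate the methyl groups' placement from the ring itself.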